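Methylphenyl isomers: from compound 2 to compound 3

A few compounds are considered here, and "the series" means these few. Any claim that something is new, unique, unknown or untested is made for them only; others in the source may bear on it.

In a toxicity assay on HaCaT cells (Homo sapiens) for cytotoxicity, read by CCK-8 assay, with a stated time of 24 h (a higher number here means that more compound is tolerated, a lower number that less compound is tolerated), compound 1 (`COc1ccccc1Oc1c(N)nc(-c2ccccc2)nc1Cl`) is recorded as "not active" (no number reported), with no number given. Among the measured compounds shown here, compound 2 (`COc1ccccc1Oc1c(N)nc(-c2cccc(C)c2)nc1Cl`) gives 11200 nM, the only number so far, so it has no measured figure to be ranked against.

The next entry is compound 3 (`COc1ccccc1Oc1c(N)nc(-c2ccc(C)cc2)nc1Cl`), not yet measured in this assay. The change is 4-methylphenyl in place of 3-methylphenyl on an aromatic carbon, with the same atoms joined differently. For the measured compounds named here, no step between measured compounds is available to calibrate this change, so no direction can be assigned, and nothing beyond the usual scatter is expected. The expected 1.1-fold higher number from compound 2 to compound 3 (0.03 log units; within the scatter) is therefore small. Compound 1, at "not active" (no number reported), shows that a result without a number remains possible. For compound 3, the estimated value is 12000 nM, with an expected range of 5000 nM to 30000 nM.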

Compound 3, half-maximal cytotoxic concentration: 6300 nM
Compound 3: middle estimate off by 1.9-fold (0.28 log units), on the high side; low and high end bracket the measured number.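

In this assay the series now has its first readable step at this position, and a 1.8-fold lower number from compound 2 to compound 3 (0.25 log units; within the scatter) is what 4-methylphenyl in place of 3-methylphenyl amounts to on this aromatic carbon between two ring nitrogen atoms. The step lies within the scatter, so compound 2 and compound 3 cannot be told apart, and the two methylphenyl isomers give no sign that the placement of the methyl group matters here. Nothing measured alongside these compounds bears on the result.

Compound 1 carries no number, so its steps to the methylphenyl compounds cannot be read. From the compounds shown here alone, whether an amine, a carboxylic acid or a longer chain in place of the methyl group would stay within the same range remains open.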